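The compounds below may be only part of what the source reports. "The series", "measured", "known", "first", "only" and "open" are said of these compounds alone.

Three analogues of the shared core carry a value in a functional assay on MCF7 cells (Homo sapiens) for inhibition, read by MTT assay, with a stated time of 48 h; a higher number here means a weaker inhibitor, a lower number a stronger inhibitor. Compound 1 `Brc1ccc(CSc2nnc(-c3ccncc3)n2-c2ccccc2)cc1` gives 12600 nM. Compound 2 `O=C(CSc1nnc(-c2ccncc2)n1-c1ccccc1)N/N=C/c1ccccc1` gives 23600 nM, and compound 3 `O=C(CSc1nnc(-c2ccncc2)n1-c1ccccc1)N/N=C/c1ccccc1F` gives 22400 nM; compound 3 thus stands second highest of the three numbers, though its gaps to compound 2 and to compound 1 are both within the scatter. For the measured compounds named here, the only recorded single-point step, a 1.1-fold lower number from compound 2 to compound 3 (0.02 log units; within the scatter), is within the scatter. Compound 4 `O=C(CSc1nnc(-c2ccncc2)n1-c1ccccc1)N/N=C/c1ccc(O)c(O)c1` is the next step: 3,4-dihydroxyphenyl in place of 2-fluorophenyl on a carbon with a double bond to nitrogen. Going by the values given here, no measured step replaces a whole substituted ring on that carbon; the one ring-substituent change, a 1.1-fold lower number from compound 2 to compound 3 (0.02 log units; within the scatter), moved nothing beyond the scatter. A step of comparable size, a 1.2-fold lower number from compound 3 to compound 4 (0.09 log units; within the scatter), is therefore expected in this assay, direction undetermined. Compound 4 is estimated at 18000 nM, within 7000 nM to 45000 nM.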

Compound 4, half-maximal inhibitory concentration: 19700 nM
The estimate for compound 4 lay 1.1-fold (0.04 log units) below the measured number; the range from low to high includes it.
By their numbers in this assay, from the lowest: compounds 1, 4, 3 and 2 (each within the scatter of the next).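

Exchanging a whole ring on the carbon with a double bond to nitrogen, not just one ring substituent, still gives no step beyond the scatter in this assay (a 1.1-fold lower number from compound 3 to compound 4 (0.06 log units; within the scatter); a 1.2-fold lower number from compound 2 to compound 4 (0.08 log units; within the scatter)). Hydrogen-bond donors and acceptors enter with the 3,4-dihydroxyphenyl, yet compound 2, compound 3 and compound 4 remain within the scatter of one another. No evidence is available to explain this result.

From the compounds shown here alone, whether an amine, a carboxylic acid or a longer chain at this place would give a step beyond the scatter stays open. Also open, going by these compounds, is whether this flat picture holds on other cell lines.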